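Aryl replacement at the carbonyl carbon: compound 2 to compound 4

The source may report more compounds than this note shows. Statements on the series, on what has been measured and on what is new or still open speak of the compounds shown alone.

Measured so far in a functional assay on MOLT-4 cells (Homo sapiens) for cytotoxicity, read by sulforhodamine B assay, with a stated time of 48 h, tested at 100 uM; a lower number here means a stronger effect, a higher number a weaker effect of the compound at the concentration tested:
compound 1 `COc1cc(-c2cc(/C=C/C(=O)c3ccc(N)cc3)[nH]n2)cc(OC)c1OC`: -20%
compound 2 `COc1cc(-c2cc(/C=C/C(=O)c3ccc(Cl)c(Cl)c3)[nH]n2)cc(OC)c1OC`: -15%
compound 3 `COc1ccc(-c2cc(/C=C/C(=O)c3cc(OC)c(OC)c(OC)c3)[nH]n2)cc1OC`: -15%

Among the measured compounds shown here, compound 2 sits level with compound 3 at the digits reported, and the only measured step at the carbonyl carbon, a number 5 percentage points higher from compound 1 to compound 2 (within the scatter), is within the scatter; all three numbers lie within the scatter of one another.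

Compound 4 `COc1ccc(C(=O)/C=C/c2cc(-c3cc(OC)c(OC)c(OC)c3)n[nH]2)cc1` differs from compound 2 by 4-methoxyphenyl in place of 3,4-dichlorophenyl on a carbonyl carbon. For the measured compounds named here, the one step that bears on this change, a number 5 percentage points higher from compound 1 to compound 2 (within the scatter), gave no shift beyond the scatter, so no step beyond the scatter is expected in this assay either.

Compound 4 is therefore expected to give -15%, between -35% and 5%, an expected step of no change at the digits printed from compound 2 to compound 4 (within the scatter).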

Compound 4, a percentage reported as activity, at one concentration (the size of the read-out at that concentration, not a potency): -4%
Beside the measured number, compound 4's estimate is 11 percentage points below it, and the stated range covers the measured number.
By their numbers in this assay, from the lowest: compounds 1, 2 and 3 (each within the scatter of the next); then compound 4.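

In this assay the aryl group on a carbonyl carbon now shows a step beyond the scatter: 4-methoxyphenyl in place of 3,4-dichlorophenyl gives a number 11 percentage points higher from compound 2 to compound 4 (beyond the scatter). Methoxy in place of amino on an aromatic carbon likewise gives a number 16 percentage points higher from compound 1 to compound 4 (beyond the scatter). This place therefore responds to its substituent, which the earlier step alone did not show, and both modest steps run towards a weaker effect. No available evidence explains this change. From the compounds shown here alone, it remains open whether a carboxylic acid or a longer alkoxy chain on this aryl ring would shift the number further, and in which direction.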